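The compounds below may be only part of what the source reports. "The series", "measured", "known", "first", "only" and "open" are said of these compounds alone.

Compound 1 `CN(C)c1ncnc2c1c(-c1cc3ccccc3o1)cn2[C@@H]1O[C@H](CO)[C@@H](O)[C@H]1O`: > 20000 nM in a functional assay on HL-60 cells (Homo sapiens) for antiproliferative activity, read by XTT assay, with a stated time of 72 h; a lower number here means a stronger inhibitor, a higher number a weaker inhibitor
Compound 2 `Cc1ncnc2c1c(-c1cc3ccccc3o1)cn2[C@@H]1O[C@H](CO)[C@@H](O)[C@H]1O`: > 20000 nM in this assay

Both of these values are limits of this assay rather than numbers. Compound 1 therefore stands only as a limit in this assay, and the one companion shown beside it, compound 2, is a limit as well. Among the compounds with values here, the single measured step, a step that the two limits leave unreadable from compound 1 to compound 2, cannot be read in either direction, because both values sit at the limit of > 20000 nM in this assay, at which 2 of the 2 values shown sit. Nothing in the measured pair bears on the position that is altered in the unmeasured compound.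

Compound 3 `CN(C)c1ncnc2c1c(-c1cccs1)cn2[C@@H]1O[C@H](CO)[C@@H](O)[C@H]1O` differs from compound 1 in one place: thiophen-2-yl in place of 1-benzofuran-2-yl on an aromatic carbon. Within the data shown here, no measured step touches this part of the shared core, so the only anchor for compound 3 is that compound 1 itself is at the limit. On that basis compound 3 is expected to remain at or near the limit in this assay, with an expected step that the limit leaves unreadable from compound 1 to compound 3 that is not beyond the scatter. The estimate for compound 3 in this assay is 25000 nM, within a range from 5000 nM to 100000 nM.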

Compound 3, half-maximal inhibitory concentration: 11800 nM
Estimate against measurement, compound 3: 2.1-fold (0.33 log units) above; measured number inside the range.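

Replacing 1-benzofuran-2-yl with thiophen-2-yl, on the aromatic carbon two ring bonds from the ring nitrogen, yields the first actual number rather than a limit in this assay: compound 3 gives 11800 nM. Going by these compounds, the change reads as an at least 1.6-fold lower number from compound 1 to compound 3 (0.22 log units; that floor lies within the scatter), and only this floor can be stated, so the full size of the step remains unknown and the floor alone does not establish a change beyond the scatter. This is still the only step shown with any readable size, while the step from dimethylamino to methyl cannot be read, and the comparison rests on a starting point that is a limit: the limit of > 20000 nM in this assay, at which 2 of the 3 values shown sit.

On these data alone, it remains open whether the number for compound 3 goes with the sulfur of the thiophen-2-yl group or with the absence of the six-membered aromatic ring, a question that a furan-2-yl or phenyl group on this carbon would help to separate. As far as these compounds go, it is also open whether a methyl group or a primary amine in place of dimethylamino, with thiophen-2-yl kept on the shared core, would give a number or a limit.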